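The source may report more compounds than this note shows. Statements on the series, on what has been measured and on what is new or still open speak of the compounds shown alone.

Among the compounds measured in an assay on lysate for inhibition of 6-phosphofructo-2-kinase/fructose-2,6-bisphosphatase 3 (Homo sapiens), with stated times of 0.5 min and 45 min (on this read-out higher numbers stand for weaker inhibition and lower numbers for stronger inhibition), compound 3 `CN1CCC(NC(=O)c2ccncc2Nc2cc(-c3ccc4ccn(C)c4c3)c3nccnc3c2)CC1` gives 19500 nM, the lowest of the two numbers known. Compound 2 `Cn1cc(NC(=O)c2ccncc2Nc2cc(-c3ccc4ccn(C)c4c3)c3nccnc3c2)cn1` gives 26500 nM, and the gap a 1.4-fold lower number from compound 2 to compound 3 (0.13 log units; within the scatter) lies within the usual scatter. For compound 1 `CN(C)C(=O)c1ccncc1Nc1cc(-c2ccc3ccn(C)c3c2)c2nccnc2c1` the assay reports only a limit, > 100000 nM (the limit of > 100000 nM in this assay, at which 1 of the 3 values shown sits). Compound 4 `CC(=O)N1CCCC(NC(=O)c2ccncc2Nc2cc(-c3ccc4ccn(C)c4c3)c3nccnc3c2)C1` differs from compound 3 in that (1-acetylpiperidin-3-yl in place of 1-methylpiperidin-4-yl on an amide-type nitrogen). The steps of an at least 3.7-fold lower number from compound 1 to compound 2 (0.57 log units; beyond the scatter) and an at least 5.1-fold lower number from compound 1 to compound 3 (0.70 log units; beyond the scatter) show that replacing dimethylamino on the carbonyl carbon by an amino group carrying a ring lowers the number, while the swap between two such rings, a 1.4-fold lower number from compound 2 to compound 3 (0.13 log units; within the scatter), stayed within the scatter. The change to compound 4 again exchanges one ring for another, so no step beyond the scatter is expected, a 1.3-fold higher number from compound 3 to compound 4 (0.11 log units; within the scatter). Compound 4 is therefore estimated at 25000 nM, with a range from 8000 nM to 80000 nM.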

Compound 4, half-maximal inhibitory concentration: 13500 nM
Estimate against measurement, compound 4: 1.9-fold (0.27 log units) above; low and high end bracket the measured number.
By their numbers in this assay, from the lowest: compounds 4, 3 and 2 (each within the scatter of the next). At a limit, above all of these: compound 1.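

Placing 1-acetylpiperidin-3-yl on the amide-type nitrogen gives no change that can be read against either earlier ring group (a 1.4-fold lower number from compound 3 to compound 4 (0.16 log units; within the scatter); a 2.0-fold lower number from compound 2 to compound 4 (0.29 log units; within the scatter)). This position therefore accepts a third ring group, here one with more heavy atoms and a double bond outside aromatic rings. The ring-bearing group again stands clear of dimethylamino (an at least 7.4-fold lower number from compound 1 to compound 4 (0.86 log units; beyond the scatter)), although that step rests on a limit: (the limit of > 100000 nM in this assay, at which 1 of the 4 values shown sits). Acetyl and the ring attachment point change together here, so 1-methylpiperidin-3-yl or 1-acetylpiperidin-4-yl would be needed to separate them. On these data alone, whether morpholine or an open alkyl chain fits this position also remains open.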